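The source may hold more compounds than are shown below. What is called first, only, known or untested is meant among the compounds shown, and "the series" means these compounds.

Measured so far in an ADME assay on microsomes from liver (Homo sapiens) for metabolic stability, read by LC-MS, using NADPH, with stated times of 5 min and 30 min, tested at 1 uM; on this read-out higher numbers stand for fast clearance and lower numbers for slow clearance:
compound 1 `O=C(Nc1ccccc1)c1cnc(NCc2c(F)ccc3c2CCO3)n2cnnc12` gives 14 mL.min-1.g-1;
compound 2 `CC1(C)CC(=O)N(c2cnc(NCc3c(F)ccc4c3CCO4)n3cnnc23)C1` gives 16 mL.min-1.g-1;
compound 3 `CN(C(=O)c1ccccc1)c1cnc(NCc2c(F)ccc3c2CCO3)n2cnnc12` gives > 300 mL.min-1.g-1, which is a limit of the assay and not a number.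

Compound 3 therefore stands at the top of the numbers shown, its reading being only a limit, (the limit of > 300 mL.min-1.g-1 in this assay, at which 1 of the 3 values shown sits). Compound 1 and compound 2 sit close together, with a 1.1-fold higher number from compound 1 to compound 2 (0.06 log units; within the scatter). The two steps leading to compound 3 were both large: an at least 21-fold higher number from compound 1 to compound 3 (1.33 log units; beyond the scatter) and an at least 18-fold higher number from compound 2 to compound 3 (1.27 log units; beyond the scatter).

Compound 4 `O=C1CCCN1c1cnc(NCc2c(F)ccc3c2CCO3)n2cnnc12` has not yet been measured in this assay. It differs from compound 3 in one place: 2-oxopyrrolidin-1-yl in place of benzoyl(methyl)amino on an aromatic carbon. Among the compounds with values here, the step that bears most directly on this change is the one from compound 2, whose 4,4-dimethyl-2-oxopyrrolidin-1-yl is the closest relative of the 2-oxopyrrolidin-1-yl entering here; that step was an at least 18-fold higher number from compound 2 to compound 3 (1.27 log units; beyond the scatter), and the step from compound 1 pointed the same way. A large drop in this assay is therefore expected on going to compound 4, back toward the region where compound 1 and compound 2 sit.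

Given that compound 2 gives 16 mL.min-1.g-1, compound 4 is estimated at 20 mL.min-1.g-1, with a range from 8 mL.min-1.g-1 to 60 mL.min-1.g-1. That estimate corresponds to an expected at least 15-fold lower number from compound 3 to compound 4 (1.17 log units; beyond the scatter).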

Compound 4, intrinsic clearance in microsomes: < 3 mL.min-1.g-1
Compound 4: no number, only a limit; the forecaster's own chance of this, stated with the estimate: 5%; at least 6.6-fold (0.82 log units) between middle value and limit.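

In this assay, as far as these compounds go, the change at this aromatic carbon spans the whole measured range, with an at least 100-fold lower number from compound 3 to compound 4 (2.00 log units; beyond the scatter), and that step runs from one limit of the assay to another, so its true size is unknown. The position also separates two closely related lactams: taking away the two methyl groups of the 4,4-dimethyl-2-oxopyrrolidin-1-yl gives an at least 5.3-fold lower number from compound 2 to compound 4 (0.72 log units; beyond the scatter), and the phenylcarbamoyl group, which had matched that dimethyl lactam with a 1.1-fold higher number from compound 1 to compound 2 (0.06 log units; within the scatter), now also stands apart, with an at least 4.6-fold lower number from compound 1 to compound 4 (0.66 log units; beyond the scatter). The reading of compound 4 is itself a limit of the assay and not a number: the limit of < 3 mL.min-1.g-1 in this assay, at which 1 of the 4 values shown sits.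

The compounds shown leave open how far the unsubstituted ring really lies under that limit, and whether a single methyl on the 2-oxopyrrolidin-1-yl ring would already move the reading toward that of the dimethyl lactam. They also leave open how a six-membered 2-oxopiperidin-1-yl ring, an open-chain acetamide, or an amine such as morpholine would read at this same position on the shared core.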